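The compounds below may be only part of what the source reports. "The series", "measured", "known", "first", "only" and "open" are said of these compounds alone.

Measured compounds: compound 1 `Cc1cc(-n2cc(C(=O)Nc3cc(F)cc(F)c3)c(=O)c3ccc(N(C)C)nc32)ccc1OCCCCCCC[N+]12CCN(CC1)CC2` gives 20.8%; compound 2 `Cc1cc(-n2cc(C(=O)Nc3cc(F)cc(F)c3)c(=O)c3ccc(N(C)C)nc32)ccc1OCCCCCCC[N+]1(C)CCCC1` gives 35.9%; compound 3 `CC[N+]1(CCCCCCCOc2ccc(-n3cc(C(=O)Nc4cc(F)cc(F)c4)c(=O)c4ccc(N(C)C)nc43)cc2C)CCCCC1` gives 53.4%, all in an assay on LX2 cells for inhibition of COL1A1 promoter (Homo sapiens), read by a luciferase reporter, with a stated time of 24 h, tested at 50 uM; a higher number here means a stronger effect of the compound at the concentration tested, a lower number a weaker effect.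

On these numbers compound 3 stands highest, above compound 2 by a number 17.5 percentage points higher from compound 2 to compound 3 (beyond the scatter) and above compound 1 by a number 32.6 percentage points higher from compound 1 to compound 3 (beyond the scatter). Compound 4 `Cc1cc(-n2cc(C(=O)Nc3cc(F)cc(F)c3)c(=O)c3ccc(N(C)C)nc32)ccc1OCCCCCCC[N+]1(C)CCN(C)CC1` differs from compound 3 in one place: a group of 8 heavy atoms (6 carbon, 2 nitrogen; one six-membered non-aromatic ring with 2 hetero atoms) in place of a group of 8 heavy atoms (7 carbon, 1 nitrogen; one six-membered non-aromatic ring with 1 hetero atom), on a saturated chain carbon, seven bonds along the chain from an oxygen on an aromatic ring. Going by the values given here, the steps that bear on this are the ones into compound 3, above all a number 32.6 percentage points higher from compound 1 to compound 3 (beyond the scatter), where a group with two nitrogens gave way to a group with one, and the reading rose. Compound 4 brings a second nitrogen back into the ring, so a step downward beyond the scatter is expected, a number 19.4 percentage points lower from compound 3 to compound 4 (beyond the scatter). For compound 4 the expected reading in this assay is 34%, within 15% to 55%.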

Compound 4, a percentage reported as inhibition, at one concentration (the size of the read-out at that concentration, not a potency): 32%
The estimate for compound 4 lay 2 percentage points above the measured number; measured number inside the range.
By their numbers in this assay, from the lowest: compound 1; then compounds 4 and 2 (each within the scatter of the next); then compound 3.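

In this assay, the six-membered ring with 2 hetero atoms at the chain end reads clearly lower than the ring with 1 hetero atom (a number 21.4 percentage points lower from compound 3 to compound 4 (beyond the scatter)). So the drop seen with the two-ring group also appears with a second nitrogen in a single ring, though that single ring still reads higher than the group of 2 rings (a number 11.2 percentage points higher from compound 1 to compound 4 (beyond the scatter)). It cannot be told apart from the five-membered ring group (a number 3.9 percentage points lower from compound 2 to compound 4 (within the scatter)). No measurement offered here accounts for these differences. As far as these compounds go, whether a morpholine ring, with oxygen in place of the second nitrogen, would behave like either ring remains open.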